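Swapping the thiazolyl amide of compound 1 for phenyl

The source may hold more compounds than are shown below. What is called first, only, known or untested is meant among the compounds shown, and "the series" means these compounds.

Compound 1 `O=C(CCCCCCNC(=O)C(O)(O)C(F)(F)F)Nc1nccs1` gives 10800 nM in a functional assay on HCT-116 cells (Homo sapiens) for inhibition, read by colorimetric assay, with a stated time of 3 days (a higher number here means a weaker inhibitor, a lower number a stronger inhibitor), the highest of the two numbers in hand. Its nearest neighbour is compound 3 `O=C(CCCCCCNC(=O)C(O)(O)C(F)(F)F)Nc1ncc(-c2ccc(O)cc2)s1`, which gives 1020 nM in this assay; the change 4-hydroxyphenyl in place of hydrogen on an aromatic carbon yields an 11-fold lower number from compound 1 to compound 3 (1.02 log units; beyond the scatter). Compound 2 `O=C(CCCCCCNC(=O)C(O)C(F)(F)F)Nc1nccs1` reaches only a limit of this assay, > 40000 nM, and so has no number. That hydrogen-in-place-of-hydroxy step reads an at least 3.7-fold higher number from compound 1 to compound 2 (0.56 log units; beyond the scatter), its size known only as a bound because of the limit of > 40000 nM in this assay, at which 1 of the 3 values shown sits.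

Compound 4 `O=C(CCCCCCNC(=O)C(O)(O)C(F)(F)F)Nc1ccccc1` differs from compound 1 by phenyl in place of 1,3-thiazol-2-yl on an amide-type nitrogen. Neither measured step touches this part of the shared core, so neither bears on it directly; the step from compound 1 to compound 3 shows only that this end of the molecule can move the number a great deal. Lacking direct evidence, compound 4 is expected to land near compound 1, perhaps somewhat weaker, a step of a 1.9-fold higher number from compound 1 to compound 4 (0.27 log units; within the scatter). Compound 4 is therefore estimated at 20000 nM, within 6000 nM to 60000 nM.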

Compound 4, half-maximal inhibitory concentration: 9140 nM
The estimate for compound 4 lay 2.2-fold (0.34 log units) above the measured number; measured number inside the range.
By their numbers in this assay, from the lowest: compound 3; then compounds 4 and 1 (each within the scatter of the next). At a limit, above all of these: compound 2.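

In this assay, phenyl in place of 1,3-thiazol-2-yl on the amide-type nitrogen gives a 1.2-fold lower number from compound 1 to compound 4 (0.07 log units; within the scatter), so the two groups cannot be told apart in this assay. The nitrogen and sulfur of the 1,3-thiazol-2-yl group can therefore be lost without a change beyond the scatter, even though this end of the molecule can shift the number strongly, as an 11-fold lower number from compound 1 to compound 3 (1.02 log units; beyond the scatter) shows. No available evidence bears on why this swap leaves the number within the scatter.

Going by these compounds, it remains open whether a 4-hydroxyphenyl group on the phenyl ring of compound 4 would lower the number as it does on the 1,3-thiazol-2-yl ring of compound 1. On these data alone, it is also open whether a pyridyl or cyclohexyl group on the same nitrogen would match phenyl.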